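The compounds below may be only part of what the source reports. "The series", "measured", "known", "first", "only" and "open" are said of these compounds alone.

Measured in a physicochemical assay for acid dissociation:
Compound 1 `CC(C)OC(=N)NC(=N)Nc1ccc(Cl)cc1`: 9.35
Compound 2 `CNC(=N)NC(=N)Nc1ccc(Cl)cc1`: 10.6

Of these two, compound 2 stands highest, at 10.6 in this assay. Compound 3 `CCNC(=N)NC(=N)Nc1ccc(Cl)cc1` differs from compound 2 by methyl in place of hydrogen on a saturated chain carbon bound to an amine nitrogen. For the measured compounds named here, the only measured step, a number 1.25 log units higher from compound 1 to compound 2 (beyond the scatter), put methylamino in place of isopropoxy. Going by the values given here, that is a different change, so it bears only loosely here, and no measured step covers this one. The step expected is no change at the digits printed from compound 2 to compound 3 (within the scatter), none beyond the scatter. For compound 3 the estimated value is 10.6, within an expected range of 10.2 to 11.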

Compound 3, acid dissociation constant: 10.8
Compound 3: middle estimate off by 0.20 log units, on the low side; the measured number falls inside the stated range.
By their numbers in this assay, from the lowest: compound 1; then compounds 2 and 3 (each within the scatter of the next).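

In this assay, ethylamino in place of methylamino gives a number 0.20 log units higher from compound 2 to compound 3 (within the scatter) and so cannot be told apart from methylamino at this position, on a saturated chain carbon bound to an amine nitrogen. With ethylamino as with methylamino, the large gap from the isopropoxy compound persists, as the replacement gives a number 1.45 log units higher from compound 1 to compound 3 (beyond the scatter) and thus holds for a second alkylamino group. Nothing available accounts for these numbers. From the compounds shown here alone, whether a longer chain such as propylamino would stay within the scatter remains open, and so does where an unsubstituted amine or a cyclic amine such as piperidine would fall.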